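Compound 3 to compound 4: ethoxy for phenyl

This account rests on a few compounds, and the source may have more. Where it says the series, first, only, none or still open, it means among the compounds named here.

Of the compounds shown here, three have been tested in a functional assay on Raji cells (Homo sapiens) for cytotoxicity, with a stated time of 72 h (on this read-out lower numbers stand for an effect already at smaller amounts and higher numbers for an effect only at larger amounts of compound), and none has yet given a number. Compound 1 (`C=C[C@@](C)(/C=C/c1ccc(O)cc1)CC/C=C(\C)C(=O)OCC`) gives > 26000 nM as a limit. Compound 2 (`C=C[C@@](C)(/C=C/c1ccc(O)cc1)CC/C=C(C)/C=C/C(=O)OCc1ccccc1`) gives > 26000 nM as a limit. Compound 3 (`C=C[C@@](C)(/C=C/c1ccc(O)c(/C=C/C(=O)c2ccccc2)c1)CCC=C(C)C`) gives > 26000 nM as a limit. Compound 3 therefore stands with the other two at the limit of > 26000 nM in this assay, at which 3 of the 3 values shown sit, and offers no number to measure from.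

On these data alone, compound 4 (`C=C[C@@](C)(/C=C/c1ccc(O)c(/C=C/C(=O)OCC)c1)CCC=C(C)C`) is still untested. It has ethoxy in place of phenyl on a carbonyl carbon, which reads as benzoyl to ethoxycarbonyl when cut one bond further out (ethoxy in place of phenyl on a carbonyl carbon). Going by the values given here, no step between measured compounds is available to size this change. In this assay no step beyond the scatter is expected, and no direction is favoured. The estimated step is a number no higher from compound 3 to compound 4 (the limit leaves the size open) in this reading. This expectation rests on compound 3 sharing the limit of > 26000 nM in this assay, at which 3 of the 3 values shown sit, with both other compounds. Compound 4 is expected at 26000 nM with an estimated range of 10000 nM to 60000 nM and a good chance of another limit.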

Compound 4, half-maximal effective concentration: > 26000 nM
Compound 4: only a limit was reported (the forecaster's own chance of this, stated with the estimate: 70%); the middle value lies on the limit itself.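

No step can be read from compound 3 to compound 4, as both values are limits and the size of any difference stays hidden: the limit of > 26000 nM in this assay, at which 4 of the 4 values shown sit.

The compounds shown leave open whether any change to this series gives a readable value in this assay and how ethoxy compares with phenyl on the carbonyl carbon.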